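From compound 1 to compound 3: one added amino group

The source may hold more compounds than are shown below. What is called first, only, known or untested is meant among the compounds shown, and "the series" means these compounds.

Compound 1 `OCC1=C(F)[C@@H](n2cnc3c(O)ncnc32)[C@H](O)[C@@H]1O`: > 100000 nM
Compound 2 `OCC1=C(F)[C@@H](n2cnc3c(NC4CC4)ncnc32)[C@H](O)[C@@H]1O`: > 100000 nM

In a functional assay on PC-3 cells (Homo sapiens) for cytotoxicity, read by sulforhodamine B assay, with a stated time of 72 h (on this read-out lower numbers stand for stronger inhibition and higher numbers for weaker inhibition), compound 1 gives > 100000 nM, which is a limit and not a number. Compound 2 gives > 100000 nM, also a limit. Going by the values given here, the only measured step, a step that the two limits leave unreadable from compound 1 to compound 2, has no readable size, and it concerns a different place on the core. Compound 3 `Nc1nc(O)c2ncn([C@@H]3C(F)=C(CO)[C@@H](O)[C@H]3O)c2n1` differs from compound 1 by amino in place of hydrogen on an aromatic carbon. With compound 1 at the limit of > 100000 nM in this assay, at which 2 of the 2 values shown sit, no clear step is expected in this assay, and any readable shift would be toward stronger inhibition. The expected change is a number no higher from compound 1 to compound 3 (the limit leaves the size open). Compound 3 is estimated at 100000 nM, with an expected range from 30000 nM to 200000 nM.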

Compound 3, half-maximal inhibitory concentration: > 100000 nM
Compound 3 gave a limit, no number (the forecaster's own chance of this, stated with the estimate: 85%); the middle value lies on the limit itself.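

Compound 3, like compound 1, gives only a limit, so no step can be read between compound 1 and compound 3. The compounds shown leave open whether amino in place of hydrogen shifts the read-out at all, since all of them rest on one value: the limit of > 100000 nM in this assay, at which 3 of the 3 values shown sit.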